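The compounds below may be only part of what the source reports. "The series", "measured", "known", "first", "only" and "open" are said of these compounds alone.

In a functional assay on PC-3 cells (Homo sapiens) for cytotoxicity, read by MTT assay, with a stated time of 48 h (on this read-out higher numbers stand for weaker inhibition and lower numbers for stronger inhibition), compound 1 `COc1ccc(-c2c[nH]c(=O)n2-c2cc(OC)c(OC)c(OC)c2)cc1` is recorded only as a limit, > 50000 nM. Among the compounds with values here, compound 2 `COc1cc(-n2c(-c3ccc([N+](=O)[O-])cc3)cn(C(C)=O)c2=O)cc(OC)c1OC`, which carries a 4-nitrophenyl group, gives 32900 nM, the only true number available so far, so it has no measured neighbour to be ranked against.

Compound 3 `COc1ccc(-c2cn(C(C)=O)c(=O)n2-c2cc(OC)c(OC)c(OC)c2)cc1` differs from compound 2 in one place: methoxy in place of nitro on an aromatic carbon, para to a large group, which turns the 4-nitrophenyl into 4-methoxyphenyl (methoxy in place of nitro on an aromatic carbon). Within the data shown here, no measured pair of compounds shows this change, so the expectation in this assay is for no step beyond the usual scatter of repeated measurements. The estimated move is a 1.3-fold lower number from compound 2 to compound 3 (0.12 log units; within the scatter). Compound 3 is expected at 25000 nM, with an estimated range from 5000 nM to 60000 nM.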

Compound 3, half-maximal inhibitory concentration: 19700 nM
The estimate for compound 3 lay 1.3-fold (0.10 log units) above the measured number; the measured number falls inside the stated range.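

In this assay, placing methoxy instead of nitro on the aromatic carbon para to a large group gives a 1.7-fold lower number from compound 2 to compound 3 (0.22 log units; within the scatter), so this position tolerates either group without a change that can be told from the scatter. The acetyl on the aromatic nitrogen is the change that registers, as acetyl in place of hydrogen gives an at least 2.5-fold lower number from compound 1 to compound 3 (0.40 log units; beyond the scatter). That step has only a minimum size, and its true size stays unknown, as compound 1 is recorded as a limit and not a number: the limit of > 50000 nM in this assay, at which 1 of the 3 values shown sits.

Going by these compounds, the 4-nitrophenyl group appears here only together with the acetyl, so it remains open whether the acetyl step would be the same with that group. On these data alone, how an amine or a carboxylic acid at the same para place would read also remains open.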